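The source may hold more compounds than are shown below. What is called first, only, known or untested is meant among the compounds shown, and "the series" means these compounds.

Compound 2 `COc1ccc(/C=C/c2cc(OC)cc(OC)c2/C=C/C(=O)c2ccc(C)cc2)cc1` is the stronger of the two measured compounds: in a functional assay on HepG2 cells (Homo sapiens) for antiproliferative activity, read by MTT assay, with a stated time of 48 h (a lower number here means a stronger inhibitor, a higher number a weaker inhibitor), compound 2 gives 4.8 ug/mL. Compound 1 `CCCCOc1ccc(C(=O)/C=C/c2c(/C=C/c3ccc(OC)cc3)cc(OC)cc2OC)cc1` carries a butoxy where compound 2 carries a methyl, and in this assay compound 1 gives 12.9 ug/mL, so the change from butoxy to methyl gave a 2.7-fold lower number from compound 1 to compound 2 (0.43 log units; beyond the scatter). Compound 3 `COc1ccc(/C=C/c2cc(OC)cc(OC)c2/C=C/C(=O)c2ccc(-c3ccccc3)cc2)cc1` is the next member, and it differs from compound 2 at that same aromatic carbon: phenyl in place of methyl on an aromatic carbon. Going by the values given here, the only step that bears on this position is the one from compound 1 to compound 2, and it was modest. Since the group that enters in compound 3 is again larger than methyl, as butoxy was, compound 3 is expected to show a modest rise, a 1.7-fold higher number from compound 2 to compound 3 (0.22 log units; within the scatter), though a result within the scatter would not surprise. The estimate for compound 3 in this assay is therefore 8 ug/mL, with a range from 3 ug/mL to 20 ug/mL.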

Compound 3, half-maximal inhibitory concentration: 10.5 ug/mL
Estimate against measurement, compound 3: 1.3-fold (0.12 log units) below; the measured number falls inside the stated range.
By their numbers in this assay, from the lowest: compound 2; then compounds 3 and 1 (each within the scatter of the next).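

In this assay, methyl at this aromatic carbon, para to a large group, now has a second replacement, and phenyl for methyl gives a 2.2-fold higher number from compound 2 to compound 3 (0.34 log units; beyond the scatter), so among these three compounds methyl is the group with the lowest number. Phenyl for butoxy gives a 1.2-fold lower number from compound 1 to compound 3 (0.09 log units; within the scatter), so a chain and an aromatic ring at this carbon cannot be told apart here, and both stand apart from methyl. No measurement at hand explains why methyl differs from these two larger groups.

On these data alone, it remains open whether a shorter chain such as ethoxy would read like methyl or like butoxy. Nor do these compounds show what hydrogen, fluorine, an amine or a carboxylic acid would give at this carbon.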